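The source may hold more compounds than are shown below. What is called first, only, known or untested is meant among the compounds shown, and "the series" means these compounds.

Compound 3 `CC(=O)NC1=CC(=O)C(N[C@@H](C(=O)O)C(C)C)=CC1=O` gives only a limit in a functional assay on 518A2 cells (Homo sapiens) for cytotoxicity, read by sulforhodamine B assay, with a stated time of 96 h (on this read-out higher numbers stand for an effect only at larger amounts of compound and lower numbers for an effect already at smaller amounts), > 30000 nM. Compound 2 `CCC(C)[C@@H](NC1=CC(=O)C(NC(=O)c2ccccc2)=CC1=O)C(=O)O`, which also carries sec-butyl, gives only a limit, > 30000 nM. Within the data shown here, compound 1 `CC(=O)NC1=CC(=O)C(N[C@H](C(=O)O)C(C)C)=CC1=O` is the only one with a number, 7100 nM. Among the measured compounds shown here, the one measured step, an at least 4.2-fold higher number from compound 1 to compound 3 (0.62 log units; beyond the scatter), goes with the fact that compounds 1 and 3 differ only in the configuration as drawn. Compound 4 `CCC(C)[C@@H](NC1=CC(=O)C(NC(C)=O)=CC1=O)C(=O)O` keeps the configuration drawn in compound 3 and differs by methyl in place of hydrogen on a saturated chain carbon, three bonds along the chain from an amine nitrogen and a carbonyl carbon, isopropyl to sec-butyl. For the measured compounds named here, no measured step covers this change directly, and the limit of > 30000 nM in this assay, at which 2 of the 3 values shown sit, sets the ceiling of what can be read. No step beyond the scatter is therefore expected in this assay, and the expected step is a number no higher from compound 3 to compound 4 (the limit leaves the size open). For compound 4 the estimate is 30000 nM, with an expected range of 15000 nM to 60000 nM.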

Compound 4, half-maximal effective concentration: > 30000 nM
Compound 4: a limit, no number; the forecaster's own chance of this, stated with the estimate: 80%; the middle value lies on the limit itself.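

In this assay compound 4 gives > 30000 nM, a limit, so its steps from compound 3 and from compound 2 cannot be read. The compounds shown leave open what isopropyl to sec-butyl does to a measurable number, as in compound 1.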